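The source may report more compounds than this note shows. Statements on the series, on what has been measured and on what is new or still open speak of the compounds shown alone.

Compound 1 `COc1cc([C@](O)(CCN(C)C)[C@@H](c2cc3cc(C#N)ccc3nc2OC)c2cccc(C)c2F)cc(OC(F)F)n1`: 66%
Compound 2 `COc1cc([C@](O)(CCN(C)C)[C@@H](c2cc3cc(C#N)ccc3nc2OC)c2ccnc(OC)c2OC)cc(OC(F)F)n1`: 43%

Both values come from an ADME assay on the whole organism (Mus musculus, strain CD-1) for pharmacokinetics, at a dose of 10 mg/kg by the oral route; a higher number here means that a larger share of the oral dose reaches the circulation, a lower number that a smaller share of the oral dose reaches the circulation. Compound 2 stands lower of the two, and compound 1 is the nearest value above it, at a distance beyond the scatter.

Compound 3 `COc1cc([C@](O)(CCN(C)C)[C@@H](c2cc3cc(C#N)ccc3nc2OC)c2ccnc(OC)c2OC)cc(N(C)C)n1` departs from compound 2 at one place, with dimethylamino in place of difluoromethoxy on an aromatic carbon, next to the ring nitrogen: dimethylamino in place of difluoromethoxy on an aromatic carbon.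

Among the compounds with values here, only one measured step is available, a number 23 percentage points lower from compound 1 to compound 2 (beyond the scatter). It concerns a different group, so it shows how far this assay can move within this series but gives no direction for the present exchange. Within the data shown here, no measured step tests this exchange directly. What is expected is a number 3 percentage points lower from compound 2 to compound 3 (within the scatter), with no firm direction and a wide margin on either side. For compound 3 the estimated value is 40%, with an expected range from 20% to 60%.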

Compound 3, oral bioavailability: 50%
Estimate against measurement, compound 3: 10 percentage points below, and the stated range covers the measured number.
By their numbers in this assay, from the lowest: compounds 2 and 3 (each within the scatter of the next); then compound 1.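

Within the data shown here, at the aromatic carbon next to the ring nitrogen, the earlier compounds gave no reading, since their one step concerned the group on the saturated chain carbon. Here, with 2,3-dimethoxypyridin-4-yl held in place, exchanging difluoromethoxy for dimethylamino gives a difference that cannot be told from repeat measurements in this assay (a number 7 percentage points higher from compound 2 to compound 3 (within the scatter)), so this one exchange at this position has no clear effect on the read-out. No measured information on either group bears on this result.

From the compounds shown here alone, it remains open whether the exchange would read the same with 2-fluoro-3-methylphenyl on the saturated chain carbon, as dimethylamino appears here only with 2,3-dimethoxypyridin-4-yl. Going by these compounds, it also remains open how a cyclic amine such as morpholine would read at this aromatic carbon.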